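Side-chain change from compound 3 to compound 4

The source may hold more compounds than are shown below. What is called first, only, known or untested is meant among the compounds shown, and "the series" means these compounds.

In a functional assay on HCT-116 cells (Homo sapiens) for cytotoxicity, read by MTT assay, with a stated time of 72 h (on this read-out higher numbers stand for weaker inhibition and lower numbers for stronger inhibition), compound 1 `O=C1c2c[n+]([O-])c3ccccc3c2C(=O)c2c1c1ccccc1n2Cc1cn(C[C@H](O)CO)nn1` gives 400 nM, compound 2 `O=C1c2c[n+]([O-])c3ccccc3c2C(=O)c2c1c1ccccc1n2Cc1cn(CC(O)CO)nn1` gives 250 nM and compound 3 `CCCN1CCN(CCCCn2c3c(c4ccccc42)C(=O)c2c[n+]([O-])c4ccccc4c2C3=O)CC1` gives 790 nM. Compound 3 therefore stands level with compound 1, with a 2.0-fold higher number from compound 1 to compound 3 (0.30 log units; within the scatter), and apart from compound 2, with a 3.2-fold higher number from compound 2 to compound 3 (0.50 log units; beyond the scatter).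

Compound 4 `O=C1c2c[n+]([O-])c3ccccc3c2C(=O)c2c1c1ccccc1n2CCN1CCCCC1` keeps the shared core and changes the side chain: piperidin-1-yl in place of 2-(4-propylpiperazin-1-yl)ethyl on a saturated chain carbon, two bonds along the chain from an aromatic nitrogen. In words, piperidin-1-yl replaces 2-(4-propylpiperazin-1-yl)ethyl on a saturated chain carbon, two bonds along the chain from an aromatic nitrogen.

Only the two steps into compound 3 bear on this change, since both alter the same side chain, and both are small. The remaining step, a 1.6-fold lower number from compound 1 to compound 2 (0.20 log units; within the scatter), concerns only a drawn configuration (the fact that one of compounds 1 and 2 is drawn with a defined configuration and the other without, at the place where they differ). Going by the values given here, no measured compound carries piperidin-1-yl.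

A small move to a lower number is expected in this assay, possibly none beyond the scatter, since compound 3 sits above compound 2 with a 3.2-fold higher number from compound 2 to compound 3 (0.50 log units; beyond the scatter). The expected step is a 1.6-fold lower number from compound 3 to compound 4 (0.20 log units; within the scatter).

The estimate for compound 4 is 500 nM, with an expected range of 170 nM to 1500 nM.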

Compound 4, half-maximal inhibitory concentration: 780 nM
Compound 4: the middle estimate sits 1.6-fold (0.19 log units) below what was measured; the measured number falls inside the stated range.
By their numbers in this assay, from the lowest: compounds 2, 1, 4 and 3 (each within the scatter of the next, the first and the last beyond it).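

In this assay, piperidin-1-yl in place of 2-(4-propylpiperazin-1-yl)ethyl leaves the read-out level, with a 1.0-fold lower number from compound 3 to compound 4 (0.01 log units; within the scatter), so at this place the side chain goes from 11 heavy atoms to 6 and from two ring nitrogens to one without a step beyond the scatter. Against the compounds carrying 1-(2,3-dihydroxypropyl)-1H-1,2,3-triazol-4-yl, the earlier picture holds: a 3.1-fold higher number from compound 2 to compound 4 (0.49 log units; beyond the scatter), and a 2.0-fold higher number from compound 1 to compound 4 (0.29 log units; within the scatter). Nothing on record bears on why the step from the larger side chain is so small.

The change alters chain and ring together, so the compounds shown do not separate the contribution of either. Going by these compounds, a morpholine ring or an open-chain dimethylamine on the same chain remains open, as does piperidin-1-yl on a longer chain.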